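The compounds below may be only part of what the source reports. "The series", "measured", "known", "first", "only" and "open" are said of these compounds alone.

Going by the values given here, in a functional assay on MIA PaCa-2 cells (Homo sapiens) for cytotoxicity, read by WST assay, with a stated time of 24 h (a higher number here means a weaker inhibitor, a lower number a stronger inhibitor), compound 2 (`N#C/C(=C\c1c[nH]c2cc(F)ccc12)C(=O)c1c[nH]c2ccccc12`) gives 23500 nM, the only true number among the measured compounds. Compound 1 (`N#C/C(=C\c1c[nH]c2cc(F)ccc12)C(=O)c1c[nH]c2cc(F)ccc12`) gives > 50000 nM, which is a limit of the assay. Compound 3 (`COc1ccc2[nH]cc(C(=O)/C(C#N)=C/c3c[nH]c4cc(F)ccc34)c2c1`) gives > 50000 nM, which is also a limit.

Compound 4 (`N#C/C(=C\c1c[nH]c2ccccc12)C(=O)c1c[nH]c2ccccc12`) has not yet been measured. It differs from compound 2 by one change, (hydrogen in place of fluoro on an aromatic carbon), hydrogen in place of fluoro on an aromatic carbon. The same kind of change has been measured once, at a different place in the molecule: an at least 2.1-fold lower number from compound 1 to compound 2 (0.32 log units; beyond the scatter). The other measured step, an at least 2.1-fold higher number from compound 2 to compound 3 (0.32 log units; beyond the scatter), places methoxy in place of hydrogen on an aromatic carbon and so bears on the question only indirectly. Both sizes are only bounds because of the limit of > 50000 nM in this assay, at which 2 of the 3 values shown sit.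

Among the compounds with values here, the step from compound 1 to compound 2 is thus the single precedent, and it points towards a lower number, of modest size or more, in this assay. The step expected on that basis is a 2.0-fold lower number from compound 2 to compound 4 (0.29 log units; within the scatter). For compound 4 the estimated value is 12000 nM, with an expected range from 4000 nM to 40000 nM.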

Compound 4, half-maximal inhibitory concentration: 17900 nM
Estimate against measurement, compound 4: 1.5-fold (0.17 log units) below, within the range that was stated.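

In this assay, the result gives the only step shown that runs between two true numbers: a 1.3-fold lower number from compound 2 to compound 4 (0.12 log units; within the scatter). At this position on the six-membered aromatic ring, hydrogen in place of fluoro therefore produces no difference that can be told from the scatter, whereas the same exchange at the other place in the molecule gave an at least 2.1-fold lower number from compound 1 to compound 2 (0.32 log units; beyond the scatter). The two steps cannot be compared as measured sizes, as the earlier one is only a bound, so the compounds show only that this single-atom exchange need not have the same outcome at both places: the limit of > 50000 nM in this assay, at which 2 of the 4 values shown sit.

The compounds shown leave open how this position would respond to a group larger than fluoro, such as a chloro, a methoxy, an amine or a carboxylic acid, as fluoro and hydrogen are the only two groups compared there. They also leave open whether the contrast between the two places would hold up if the earlier step were read between two true numbers, or on a core carrying a different substituent at the other place.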